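From pyridin-4-yl to phenyl on compound 3

A few compounds are considered here, and "the series" means these few. Any claim that something is new, unique, unknown or untested is made for them only; others in the source may bear on it.

Measured so far in a physicochemical assay for metabolic stability, read by HPLC (a higher number here means that the compound lasts longer, a lower number that the compound disappears faster), are these compounds
Compound 1 `O=c1ccn([C@H]2CC[C@@H](COP(=O)(O)Oc3cccnc3)O2)c(=O)[nH]1` gives 50.2 h
Compound 2 `O=c1ccn([C@H]2CC[C@@H](COP(=O)(O)Oc3ccccc3)O2)c(=O)[nH]1` gives 25.1 h
Compound 3 `Cc1cn([C@H]2C[C@H](N=[N+]=[N-])[C@@H](COP(=O)(O)Oc3ccncc3)O2)c(=O)[nH]c1=O` gives 8.07 h

Compound 3 at 8.07 h stands lowest of the three, with both other numbers higher by more than the scatter. Compound 4 `Cc1cn([C@H]2C[C@H](N=[N+]=[N-])[C@@H](COP(=O)(O)Oc3ccccc3)O2)c(=O)[nH]c1=O` has not yet been measured. It has phenyl in place of pyridin-4-yl on an oxygen. For the measured compounds named here, one measured step bears on this change, with pyridin-3-yl leaving and phenyl entering on the core of compound 1. Given a 2.0-fold lower number from compound 1 to compound 2 (0.30 log units; within the scatter) in that pair, a small drop or none beyond the scatter is expected in this assay here. Going by the values given here, that step involves a different pyridinyl group and a different core, and no step has been measured on the core of compound 3. The expected change is a 1.5-fold lower number from compound 3 to compound 4 (0.17 log units; within the scatter) by this estimate. For compound 4 the estimated half-life is 5.5 h with an expected range from 2.5 h to 12 h in this assay's terms.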

Compound 4, half-life: 9.47 h
The estimate for compound 4 lay 1.7-fold (0.24 log units) below the measured number; measured number inside the range.
By their numbers in this assay, from the lowest: compounds 3 and 4 (each within the scatter of the next); then compounds 2 and 1 (each within the scatter of the next).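

For the compounds shown here, on the core of compound 3, in this assay, replacing pyridin-4-yl with phenyl on an oxygen whose other neighbours are phosphorus gives a 1.2-fold higher number from compound 3 to compound 4 (0.07 log units; within the scatter), the first measured step on this core. Together with a 2.0-fold lower number from compound 1 to compound 2 (0.30 log units; within the scatter), which involves pyridin-3-yl on a different core, it gives two exchanges of a pyridinyl group for phenyl at this oxygen, and both lie within the scatter, so neither shows a measurable effect of this change. Nothing available explains this result.

The compounds shown leave open how this assay would read with an amine or a carboxylic acid on the phenyl ring in place of the bare ring. They also leave open whether a pyridin-2-yl group on this oxygen would stay within the scatter of phenyl.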